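Chain Length and Cytotoxicity in a Cyanoguanidine Series

A few compounds are considered here, and "the series" means these few. Any claim that something is new, unique, unknown or untested is made for them only; others in the source may bear on it.

Compound 1 `N#C/N=C1\N(CCCCCOc2ccc(Cl)cc2)C(=O)CN1c1ccncc1`: 4200 nM
Compound 2 `N#C/N=C1\N(CCCCCCOc2ccc(Cl)cc2)C(=O)CN1c1ccncc1`: 392 nM
Compound 3 `CCC1C(=O)N(CCCCCCOc2ccc(Cl)cc2)/C(=N\C#N)N1c1ccncc1`: 4350 nM

In a functional assay on HepG2 cells (Homo sapiens) for cytotoxicity (on this read-out higher numbers stand for weaker inhibition and lower numbers for stronger inhibition), compound 1 gives 4200 nM. The change (4-chlorophenoxy)methyl in place of 4-chlorophenoxy on a saturated chain carbon, five bonds along the chain from an amide-type nitrogen in a ring gives an 11-fold lower number from compound 1 to compound 2 (1.03 log units; beyond the scatter). Adding an ethyl group on the ring, an 11-fold higher number from compound 2 to compound 3 (1.05 log units; beyond the scatter), returns the number to the range of compound 1, and the difference between the cores of compound 1 and compound 3 is not broken down here.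

Compound 4 `CCC1C(=O)N(CCCCCCCOc2ccc(Cl)cc2)/C(=N\C#N)N1c1ccncc1` is not yet measured. It differs from compound 3 by (4-chlorophenoxy)methyl in place of 4-chlorophenoxy on a saturated chain carbon, six bonds along the chain from an amide-type nitrogen in a ring. This is the same kind of change as that from compound 1 to compound 2, but the place differs: six bonds along the chain rather than five. Compound 4 is expected to give 900 nM, a step of a 4.8-fold lower number from compound 3 to compound 4 (0.68 log units; beyond the scatter) estimated because an 11-fold lower number from compound 1 to compound 2 (1.03 log units; beyond the scatter) suggests a lower number, though the unmeasured core of compound 3 and the shifted place leave this uncertain.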

Compound 4, half-maximal inhibitory concentration: 3450 nM
Beside the measured number, compound 4's estimate is 3.8-fold (0.58 log units) below it; measured number inside the range.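

In this assay, the change from 4-chlorophenoxy to (4-chlorophenoxy)methyl on the core carrying the ethyl group gives a 1.3-fold lower number from compound 3 to compound 4 (0.10 log units; within the scatter), so compound 3 and compound 4 cannot be told apart. The change therefore does not carry over with the same size from one core to the other: the same change on two cores in this assay, an 11-fold lower number (1.03 log units; beyond the scatter) from compound 1 to compound 2 and a 1.3-fold lower number (0.10 log units; within the scatter) from compound 3 to compound 4, 8.5-fold (0.93 log units) apart, beyond the scatter of two such steps What sets the two steps apart is not shown, as both the core and the place on the chain differ, and two pairs give no rule for the series.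

The compounds shown leave open whether a longer chain would lower the number on either core. They also leave open what an amine in place of the 4-chlorophenoxy group would do.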